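This account rests on a few compounds, and the source may have more. Where it says the series, first, only, none or still open, it means among the compounds named here.

Measured compounds: compound 1 `C=CCn1c(=O)/c(=C\c2ccc(Cl)c(Cl)c2)[nH]c(=O)/c1=C\c1ccccc1OC` with "not active" (no number reported) in a functional assay on NCI-H1975 cells (Homo sapiens) for cytotoxicity, read by CCK-8 assay, with a stated time of 72 h; a higher number here means a weaker inhibitor, a lower number a stronger inhibitor; compound 2 `C=CCn1c(=O)/c(=C\c2ccccc2OC)[nH]c(=O)/c1=C\c1ccccc1OC` with 21500 nM in this assay.

Compound 2 holds the only number shown in this assay; compound 1 gives no number there, only the note that it was not active. Compound 3 `C=CCn1c(=O)/c(=C\c2cccc(C)c2)[nH]c(=O)/c1=C\c1ccccc1OC` differs from compound 2 by 3-methylphenyl in place of 2-methoxyphenyl on a double-bonded chain carbon bound to an aromatic carbon. Going by the values given here, no step between measured compounds is available, so the size of this change cannot be read from a neighbouring pair. Given that compound 2 is already a weak inhibitor in this assay, the expectation is a step no larger than the usual scatter, with a modest chance that compound 3 returns no number at all. Compound 3 is therefore estimated at 30000 nM in this assay, within a range of 10000 nM to 100000 nM, which means an expected step of a 1.4-fold higher number from compound 2 to compound 3 (0.14 log units; within the scatter).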

Compound 3, half-maximal inhibitory concentration: 32800 nM
Estimate against measurement, compound 3: 1.1-fold (0.04 log units) below, and the stated range covers the measured number.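

In this assay, going by these compounds alone, the exchange of 2-methoxyphenyl for 3-methylphenyl on a double-bonded chain carbon bound to an aromatic carbon comes out as a 1.5-fold higher number from compound 2 to compound 3 (0.18 log units; within the scatter) and gives the first step that can be read at this position. The entering group has no hydrogen-bond acceptor where the leaving group has one, yet the two values stand within the scatter of each other. This single pair therefore shows no measurable effect from this exchange, and nothing available bears on why.

From the compounds shown here alone, it remains open whether an amine or a carboxylic acid on an aromatic ring at this place would give a step beyond the scatter. The other 2-methoxyphenyl group stays the same in all the compounds shown, so the effect of placing a pyridine or a longer chain there also remains unknown.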